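Cytotoxicity series: nitro replacing trifluoromethoxy on the terminal ring

A few compounds are considered here, and "the series" means these few. Any claim that something is new, unique, unknown or untested is made for them only; others in the source may bear on it.

The series shares one core and varies only the group on the distal aromatic ring. Compound 1 `CCOC(=O)CCCCCOc1cccc(CN(C(=O)c2ccc(-c3cccc(NC(C)=O)c3)cc2)C(C)C)c1`, compound 2 `CCOC(=O)CCCCCOc1cccc(CN(C(=O)c2ccc(-c3ccco3)cc2)C(C)C)c1` and compound 3 `CCOC(=O)CCCCCOc1cccc(CN(C(=O)c2ccc(-c3cccc(OC(F)(F)F)c3)cc2)C(C)C)c1` have been run in an ADME assay on HEK293 cells (Homo sapiens) for cytotoxicity, read by CellTiter-Glo and resazurin assay, with a stated time of 72 h; on this read-out higher numbers stand for an effect only at larger amounts of compound and lower numbers for an effect already at smaller amounts. In this assay compound 1 returns only a limit, > 26000 nM. Compound 2 likewise gives only a limit in this assay, > 26000 nM. Compound 3 also stands at a limit in this assay, > 26000 nM, so no number is known for it. The steps among these three are therefore not readable: a step that the two limits leave unreadable from compound 1 to compound 2, a step that the two limits leave unreadable from compound 1 to compound 3 and a step that the two limits leave unreadable from compound 2 to compound 3. The one thing the data show is the limit of > 26000 nM in this assay, at which 3 of the 3 values shown sit.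

Compound 4 `CCOC(=O)CCCCCOc1cccc(CN(C(=O)c2ccc(-c3cccc([N+](=O)[O-])c3)cc2)C(C)C)c1` is the next member. It differs from compound 3 by nitro in place of trifluoromethoxy on an aromatic carbon.

For the measured compounds named here, none of the measured steps has a readable size, so there is no step to carry over. Going by the values given here, the only bearing evidence is that every compound run so far sits at the limit, and the expectation for compound 4 rests on that alone. Compound 4 is therefore expected to return a limit again in this assay, which corresponds to an expected step that the limit leaves unreadable from compound 3 to compound 4 from compound 3. The estimate for compound 4 is 40000 nM, with a range from 15000 nM to 120000 nM.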

Compound 4, half-maximal effective concentration: > 26000 nM
Compound 4 was reported as a limit; the forecaster's own chance of this, stated with the estimate: 80%; the middle value does not contradict the limit.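

Compound 4 gives only a limit in this assay, > 26000 nM. For the compounds shown here, its steps from compound 1, compound 2 and compound 3 therefore cannot be read, so no new step arises. Still open, going by these compounds, is whether these four compounds differ at all in this assay, and whether the group on the distal ring changes the value.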